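This account rests on a few compounds, and the source may have more. Where it says the series, first, only, none or still open, it means among the compounds named here.

Series notes, a physicochemical assay for lipophilicity, in phosphate buffer, measured as octanol-water partition, with a stated time of 24 h; on this read-out lower numbers stand for lower lipophilicity and higher numbers for higher lipophilicity. Of the compounds shown here, two have numbers so far. Compound 1 `S=C(N/N=C/c1ccc(Oc2ccc(Br)cc2)cc1)Nc1ccc(Br)cc1` gives 6.53 in this assay. Compound 2 `O=[N+]([O-])c1ccc(Oc2ccc(/C=N/NC(=S)Nc3ccccc3)cc2)cc1` gives 4.95 in this assay, the lower of the two numbers; compound 1 sits above it by a gap beyond the scatter of repeat measurements. Among the measured compounds shown here, no pair of measured compounds differs in only one place, so no single-point step is available yet.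

Compound 3 `Cc1cc(Oc2ccc(/C=N/NC(=S)Nc3ccccc3)cc2)ccc1Cl` has not been measured. It differs from compound 2 as follows: 4-chloro-3-methylphenyl in place of 4-nitrophenyl on an oxygen on an aromatic ring. The step from compound 2 to compound 3 is expected to be large and upward in this assay, because the halogen-bearing compound 1 gives 6.53 while the nitro-bearing compound 2 gives 4.95. For compound 3 the expected step is a number 1.45 log units higher from compound 2 to compound 3 (beyond the scatter). Compound 3 is accordingly estimated at 6.4, with a likely range from 5.9 to 6.9.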

Compound 3, partition coefficient: 6.03
The estimate for compound 3 lay 0.37 log units above the measured number; low and high end bracket the measured number.
By their numbers in this assay, from the lowest: compound 2; then compound 3; then compound 1.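

In this assay, 4-chloro-3-methylphenyl in place of 4-nitrophenyl on an oxygen on an aromatic ring gives a number 1.08 log units higher from compound 2 to compound 3 (beyond the scatter). Among the compounds shown here, this is the first single-point step, and it shows that a change at this position alone, with the rest of the core held fixed, moves the read-out beyond the scatter. The exchange alters several features at once, replacing the nitro group with chlorine and methyl, and no measurement on hand explains the size of the step.

Whether the chlorine or the methyl accounts for more of the step stays open, and a comparison with 4-chlorophenyl would address this. As far as these compounds go, the place in this assay of a phenyl ring bearing an amine or a carboxylic acid at this position also stays open.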